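A few compounds are considered here, and "the series" means these few. Any claim that something is new, unique, unknown or untested is made for them only; others in the source may bear on it.

Compound 1 `N#CC1(NC(=O)[C@@H]2C[C@@H](S(=O)(=O)c3ccccc3)C[C@H]2C(=O)N2CCCCC2)CC1` gives 0.8 nM in an assay on isolated protein for inhibition of cathepsin S (Homo sapiens), read by fluorescence, with a stated time of 20 min; a lower number here means a stronger inhibitor, a higher number a weaker inhibitor. Compound 2 `N#CC1(NC(=O)[C@@H]2C[C@@H](S(=O)(=O)c3ccccc3)C[C@H]2C(=O)N2CCC(O)CC2)CC1` gives 1 nM in this assay.

Compound 2 stands alongside compound 1, separated only by a 1.3-fold higher number from compound 1 to compound 2 (0.10 log units; within the scatter). Compound 3 `N#CC1(NC(=O)[C@@H]2C[C@@H](S(=O)(=O)c3ccccc3)C[C@H]2C(=O)N2CC(O)C2)CC1` carries 3-hydroxyazetidin-1-yl in place of 4-hydroxypiperidin-1-yl on a carbonyl carbon. Within the data shown here, no measured step touches this part of the structure; the single step measured, a 1.3-fold higher number from compound 1 to compound 2 (0.10 log units; within the scatter), concerns only the hydroxy group and lies within the scatter, so it offers no direction for the ring change. A small loss of inhibition, possibly none beyond the scatter, is expected, with the step estimated as a 2.0-fold higher number from compound 2 to compound 3 (0.30 log units; within the scatter). Compound 3 is therefore expected to give 2 nM, between 0.6 nM and 7 nM.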

Compound 3, half-maximal inhibitory concentration: 7 nM
Compound 3: the middle estimate sits 3.5-fold (0.54 log units) below what was measured; low and high end bracket the measured number.
By their numbers in this assay, from the lowest: compounds 1 and 2 (each within the scatter of the next); then compound 3.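

Unlike the hydroxy change, which stayed within the scatter, the ring on the carbonyl carbon does register in this assay: 3-hydroxyazetidin-1-yl in place of 4-hydroxypiperidin-1-yl gives a 7.0-fold higher number from compound 2 to compound 3 (0.85 log units; beyond the scatter) and so this position is not indifferent to the ring it carries. Set against the piperidin-1-yl, the same group gives an 8.8-fold higher number from compound 1 to compound 3 (0.94 log units; beyond the scatter) on the shared core. Nothing measured here accounts for the rise.

The compounds shown leave open whether the four-membered ring alone carries this step, which an unsubstituted azetidin-1-yl or a pyrrolidin-1-yl on the same carbonyl carbon would help to settle.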